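From compound 2 to compound 4: one chlorine moves

The compounds below may be only part of what the source reports. "The series", "measured", "known", "first", "only" and "open" are said of these compounds alone.

In a functional assay on K562 cells (Homo sapiens) for cytotoxicity, with a stated time of 72 h (on this read-out higher numbers stand for weaker inhibition and lower numbers for stronger inhibition), compound 2 `C[C@H](NC(=O)c1cc(Cl)ccc1O)C(=O)Nc1ccc(C(F)(F)F)cc1` gives > 12500 nM, which is a limit of the assay and not a number. Compound 3 `O=C(CNC(=O)c1cc(Cl)ccc1O)Nc1cccc(Cl)c1`, which carries the same 5-chloro-2-hydroxyphenyl group, gives > 10000 nM, again a limit. Compound 2 therefore has no exact value to serve as a starting point.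

Compound 4 `C[C@H](NC(=O)c1ccc(Cl)cc1O)C(=O)Nc1ccc(C(F)(F)F)cc1` has the same atoms as compound 2, joined differently, with 4-chloro-2-hydroxyphenyl in place of 5-chloro-2-hydroxyphenyl on a carbonyl carbon. Compound 1 `CC(C)[C@H](NC(=O)c1ccc(Cl)cc1O)C(=O)Nc1ccc(Cl)c(Cl)c1` already carries the 4-chloro-2-hydroxyphenyl group and gives > 10000 nM, also a limit.

For the measured compounds named here, no pair of tested compounds differs in one place only, so the expectation rests on these three limits. Neither form of the group has yet produced an exact value in this assay. The expected change is a number no higher from compound 2 to compound 4 (the limit leaves the size open), meaning no step beyond the usual scatter and no clear direction. The assay is expected to report a limit again. As a number, compound 4 is estimated at 12500 nM, with an expected range of 5000 nM to 30000 nM.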

Compound 4, half-maximal inhibitory concentration: > 12500 nM
Compound 4 gave a limit, no number (the forecaster's own chance of this, stated with the estimate: 85%); the middle value lies on the limit itself.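

Compound 2 and compound 4 both end at a limit of the assay rather than a number, so no step can be read from moving the chlorine: the limit of > 12500 nM in this assay, at which 2 of the 4 values shown sit.

The compounds shown leave open whether moving the chlorine changes cytotoxicity at all in this assay, since neither form of the group has an exact value there.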